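Swapping a thiophene for a furan on a shared pyridine-type core

The compounds below may be only part of what the source reports. "The series", "measured", "known", "first", "only" and "open" are said of these compounds alone.

Measured so far:
compound 1 `Oc1cccc(-c2cc(-c3ccccc3)cc(-c3ccco3)n2)c1`: 10.2%
compound 2 `Oc1ccc(-c2cc(-c3ccccc3)cc(-c3cccs3)n2)cc1`: 4.9%
compound 3 `Oc1ccc(-c2cc(-c3ccccc3)cc(-c3ccsc3)n2)cc1`: 20.4%

Three compounds that share one core and differ only in a small five-membered ring and in where a hydroxyl sits have been tested in an assay on isolated protein for inhibition of DNA topoisomerase 1 (Homo sapiens), with a stated time of 30 min, tested at 100 uM; on this read-out lower numbers stand for a weaker effect and higher numbers for a stronger effect at the one concentration tested. Compound 3 gives the highest of the three numbers; compound 1 lies below it beyond the scatter, and compound 2 lies furthest below it. Going by the values given here, the one step between compounds that differ in a single place is a number 15.5 percentage points higher from compound 2 to compound 3 (beyond the scatter), a modest gain beyond the scatter.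

The next compound, compound 4 `Oc1ccc(-c2cc(-c3ccccc3)cc(-c3ccco3)n2)cc1`, is reached from compound 3 by a single change: furan-2-yl in place of thiophen-3-yl on an aromatic carbon. Among the compounds with values here, no measured pair isolates a furan-2-yl against a thiophen-3-yl. Compound 1 carries a furan-2-yl but differs from compound 4 in the position of its hydroxyl, so its value is only a loose guide. Taken together with the step of a number 15.5 percentage points higher from compound 2 to compound 3 (beyond the scatter), which shows that moving the attachment point of the small ring can shift the read-out by more than the scatter, a downward step is expected for compound 4, roughly a number 10.4 percentage points lower from compound 3 to compound 4 (beyond the scatter). Compound 4 is therefore estimated at 10%, within a range of 0% to 25%.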

Compound 4, a percentage reported as inhibition, at one concentration (the size of the read-out at that concentration, not a potency): 18.6%
The estimate for compound 4 lay 8.6 percentage points below the measured number, within the range that was stated.
By their numbers in this assay, from the lowest: compounds 2, 1, 4 and 3 (each within the scatter of the next, the first and the last beyond it).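

At this position, on an aromatic carbon next to the ring nitrogen, furan-2-yl and thiophen-3-yl cannot be told apart in this assay (a number 1.8 percentage points lower from compound 3 to compound 4 (within the scatter)), whereas furan-2-yl in place of thiophen-2-yl gives a modest change beyond the scatter (a number 13.7 percentage points higher from compound 2 to compound 4 (beyond the scatter)), so among these three rings only thiophen-2-yl stands apart, and exchanging the ring's sulfur for oxygen does not by itself set the number. Going by these compounds alone, the pair of compound 1 and compound 4 is the first to isolate where the hydroxyl sits, and 4-hydroxyphenyl in place of 3-hydroxyphenyl stays within the scatter (a number 8.4 percentage points higher from compound 1 to compound 4 (within the scatter)), so these two hydroxyl placements cannot be told apart with furan-2-yl on the shared core. Nothing available explains why thiophen-2-yl differs from the other two rings.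

Every small ring shown here is a five-membered aromatic ring with one hetero atom, so it remains open how an amine, a carboxylic acid or a longer alkyl chain at this position would read. Every compound shown also carries a hydroxyl, which leaves open what a methoxy group or a plain phenyl would do in its place.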